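A few compounds are considered here, and "the series" means these few. Any claim that something is new, unique, unknown or untested is made for them only; others in the source may bear on it.

Compound 1 `Cc1ccccc1C(=O)NCc1ccc(CNS(=O)(=O)c2ccc(Cl)cc2)cc1` carries 4-chlorophenyl on the sulfonyl sulfur and 2-methylphenyl on the carbonyl carbon. In an assay on MDA-MB-231 cells for displacement of a labelled ligand from C-X-C chemokine receptor type 4 (Homo sapiens), read by fluorescence and microscopy, with stated times of 10 min and 30 min (a lower number here means that less compound is needed, a higher number that more compound is needed for the effect), compound 1 gives 1 nM, the lowest number of the three measured, far beyond the scatter from both others. Compound 2 `O=C(NCc1ccc(CNS(=O)(=O)c2cccc(F)c2)cc1)c1cccnc1` gives 1000 nM in this assay, and compound 3 `COc1ccccc1C(=O)NCc1ccc(CNS(=O)(=O)c2cccc(F)c2)cc1` gives 1000 nM. Going by the values given here, the one single-place step measured, no change at the digits printed from compound 2 to compound 3 (within the scatter), concerns the group on the carbonyl carbon and leaves this assay unchanged. Compound 4 `Cc1cccc(S(=O)(=O)NCc2ccc(CNC(=O)c3ccccc3C)cc2)c1` differs from compound 1 as follows: 3-methylphenyl in place of 4-chlorophenyl on a sulfonyl sulfur. Among the compounds with values here, no measured step touches the group on the sulfonyl sulfur, so no direct guide exists; compounds 1 and 2 differ in two places at once, and their values show only that the pair together spans a large gap. Going by these compounds, the 3-methylphenyl of compound 4 is untested here, so some loss from compound 1 is expected but its size is uncertain, a 20-fold higher number from compound 1 to compound 4 (1.30 log units; beyond the scatter). For compound 4 in this assay the expected value is 20 nM, within an estimated range of 1 nM to 500 nM.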

Compound 4, effective concentration (reported as EC, without a stated level of effect): 1000 nM
The estimate for compound 4 lay 50-fold (1.70 log units) below the measured number, and the stated range ends below it.
By their numbers in this assay, from the lowest: compound 1; then compounds 2, 3 and 4 (each within the scatter of the next).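

In this assay, going by these compounds alone, there is a 1000-fold higher number from compound 1 to compound 4 (3.00 log units; beyond the scatter) when 3-methylphenyl takes the place of 4-chlorophenyl on a sulfonyl sulfur, the first measured step at this position, with the rest of compound 1 kept. The two groups have the same heavy-atom count, the same six-membered aromatic ring of carbon only, no hydrogen-bond donors or acceptors and no net charge, so a change that leaves these counts untouched is enough here for a large step. No measurement in hand bears on the cause of this step.

Open, going by these compounds, is whether the step goes with the loss of the chlorine or the gain of the methyl, which a plain phenyl or a bromophenyl on the sulfonyl sulfur could help separate. Also open, on these data alone, is how this position responds to a group carrying an amine or a carboxylic acid.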